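This account rests on a few compounds, and the source may have more. Where it says the series, first, only, none or still open, it means among the compounds named here.

Compound 1 `CCOC(=O)C12C(=O)OCC=C1COC2c1ccccc1F` gives > 1000000 nM in a functional assay on QGY cells (Homo sapiens) for cytotoxicity, read by MTT assay (on this read-out lower numbers stand for stronger inhibition and higher numbers for weaker inhibition), which is a limit of the assay and not a number.
Compound 2 `CCOC(=O)C12C(=O)OCC=C1COC2c1ccc(F)cc1` gives > 1000000 nM in this assay, again a limit of the assay.
Compound 3 `CCOC(=O)C12C(=O)OCC=C1COC2c1ccc(Cl)cc1` gives > 1000000 nM in this assay, also a limit of the assay.

All three measured compounds share one core and differ only in the aryl group on a saturated ring carbon. Within the data shown here, every value so far sits at the same limit (the limit of > 1000000 nM in this assay, at which 3 of the 3 values shown sit), so no compound can be set above or below another. The step that the two limits leave unreadable from compound 1 to compound 2, the step that the two limits leave unreadable from compound 1 to compound 3 and the step that the two limits leave unreadable from compound 2 to compound 3 are all left unreadable by the two limits on either side of them. Compound 3 therefore stands only at a limit in this assay, and the two other values shown are limits as well.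

Compound 4 `CCOC(=O)C12C(=O)OCC=C1COC2c1ccc(C(C)(C)C)cc1` is the next member, differing from compound 3 by tert-butyl in place of chloro on an aromatic carbon. Among the measured compounds shown here, the only measured step at this same aromatic carbon is a step that the two limits leave unreadable from compound 2 to compound 3, which gives no readable size. For the measured compounds named here, no measured step shows a change in this assay for any exchange on the aryl group, so the step of a number no higher from compound 3 to compound 4 (the limit leaves the size open) is expected to be none readable. For compound 4 the expected value in this assay is 1000000 nM, within 200000 nM to 5000000 nM, most likely reported again as a limit.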

Compound 4, half-maximal inhibitory concentration: > 1000000 nM
Compound 4: no number, only a limit; the forecaster's own chance of this, stated with the estimate: 85%; the middle value lies on the limit itself.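

Compound 4 stands only at a limit of the assay in this assay, so its steps from compound 2 and compound 3 cannot be read: the limit of > 1000000 nM in this assay, at which 4 of the 4 values shown sit.

The compounds shown leave open whether any aryl group on the shared core gives a readable number in this assay, and the order of these four compounds remains unsettled.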